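The source may hold more compounds than are shown below. What is called first, only, known or untested is meant among the compounds shown, and "the series" means these compounds.

Measured so far in a functional assay on NCI-H460 cells (Homo sapiens) for inhibition, read by MTT assay, with a stated time of 48 h; on this read-out lower numbers stand for stronger inhibition of growth and higher numbers for weaker inhibition of growth:
compound 1 `COc1ccc(-c2cc(-c3ccc([N+](=O)[O-])cc3)[nH]n2)cc1`, 18300 nM
compound 2 `COc1ccc(-c2cc(-c3ccccc3)n[nH]2)cc1`, 10400 nM
compound 3 `COc1ccc(-c2cc(-c3ccccc3-c3ccccc3)n[nH]2)cc1`, 730 nM

Compound 3 stands lowest of the three numbers in this assay. For the measured compounds named here, the only measured single-point step, a 14-fold lower number from compound 2 to compound 3 (1.15 log units; beyond the scatter), sits on the phenyl-bearing side of the shared core. Compound 4 `Nc1ccc(-c2cc(-c3ccccc3-c3ccccc3)n[nH]2)cc1` differs from compound 3 by amino in place of methoxy on an aromatic carbon. Going by the values given here, no measured step touches the methoxy group, and compounds 1 and 2 differ from each other in more than one place, so their two values give no guide to this change. With nothing bearing on it, no step beyond the scatter is expected. Compound 4 is therefore estimated at 730 nM, within a range of 250 nM to 2200 nM. This corresponds to an expected step of no change at the digits printed from compound 3 to compound 4 (within the scatter).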

Compound 4, concentration for 50% growth inhibition: 8200 nM
Estimate against measurement, compound 4: 11-fold (1.05 log units) below, and the stated range ends below it.
By their numbers in this assay, from the lowest: compound 3; then compounds 4, 2 and 1 (each within the scatter of the next, the first and the last beyond it).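

In this assay amino in place of methoxy gives an 11-fold higher number from compound 3 to compound 4 (1.05 log units; beyond the scatter) on this ring, so this position, para to a large group and untouched by the earlier single-place step, responds to change. 4-Aminophenyl does not serve as a replacement for 4-methoxyphenyl here. Nothing at hand says which difference between the two groups accounts for the step.

Open, going by these compounds, is how a hydroxyl, ethoxy or dimethylamino group at this position would compare with methoxy and amino. Also open, on these data alone, is whether the gain from the added phenyl carries over when amino replaces methoxy.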